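This account rests on a few compounds, and the source may have more. Where it says the series, first, only, none or still open, it means among the compounds named here.

Working notes on the series in an ADME assay on MDCK-II cells (Canis lupus familiaris) for inhibition, read by MTT assay, with a stated time of 72 h; a higher number here means a weaker inhibitor of growth, a lower number a stronger inhibitor of growth:
- compound 1 `COc1cccc(/C=C/C(=O)c2ccc(OCC(=O)Nc3ccc(OC)c(OC)c3)cc2)c1`: 33200 nM
- compound 2 `Cc1ccc(-c2c(OCC(=O)Nc3cccc4ccccc34)oc3ccccc3c2=O)cc1`: "not determined" (no result reported)
- compound 3 `COc1ccc(NC(=O)COc2ccc(C(=O)/C=C/c3cc(OC)c(OC)c(OC)c3)cc2)cc1OC`: 18900 nM

Compound 2 gives no number, so only compound 1 and compound 3 can be compared, and these two lie within the scatter of each other. Compound 4 `COc1ccc(NC(=O)COc2ccc(C(=O)/C=C/c3c(F)cccc3F)cc2)cc1OC` is next, with 2,6-difluorophenyl in place of 3,4,5-trimethoxyphenyl on a double-bonded chain carbon bound to a double-bonded chain carbon. Among the measured compounds shown here, one measured step bears on this place: a 1.8-fold lower number from compound 1 to compound 3 (0.24 log units; within the scatter). For the measured compounds named here, no measured compound carries 2,6-difluorophenyl, so this guide is weak and the range stays wide. No step beyond the scatter is expected in this assay, and no direction is favoured. The expected step is a 1.2-fold higher number from compound 3 to compound 4 (0.07 log units; within the scatter). For compound 4 the estimate is 22000 nM, with an expected range of 8000 nM to 55000 nM.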

Compound 4, concentration for 50% growth inhibition: 36200 nM
Compound 4: the middle estimate sits 1.6-fold (0.22 log units) below what was measured, within the range that was stated.
By their numbers in this assay, from the lowest: compounds 3, 1 and 4 (each within the scatter of the next).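

In this assay, the position on a double-bonded chain carbon bound to a double-bonded chain carbon accepts 2,6-difluorophenyl, a group with 0 hydrogen-bond acceptors, in place of two methoxy-bearing groups: the change gives a 1.9-fold higher number from compound 3 to compound 4 (0.28 log units; within the scatter) and a 1.1-fold higher number from compound 1 to compound 4 (0.04 log units; within the scatter) and so the methoxy groups are not shown to be needed here. All three compounds at this position now lie within the scatter of one another. Nothing measured on hand accounts for these numbers.

As far as these compounds go, whether any group at this position can give a step beyond the scatter remains open. An amine or a carboxylic acid here would test that, since only neutral aromatic rings of carbon are compared so far.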